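Removing One Methoxy Group from Compound 1

The source may report more compounds than this note shows. Statements on the series, on what has been measured and on what is new or still open speak of the compounds shown alone.

In a functional assay on HepG2 cells (Homo sapiens) for inhibition, read by MTT assay, with a stated time of 48 h (on this read-out lower numbers stand for stronger inhibition and higher numbers for weaker inhibition), compound 1 `COc1ccc(-c2nc3c(c(-c4ccccc4)nn3-c3ccccc3)c(-c3ccc(N4CCCCC4)cc3)c2C#N)cc1` gives 12500 nM. This is the second highest of three numbers. Compound 3 `c1ccc(-c2nn(-c3ccccc3)c3nccc(-c4cccs4)c23)cc1` gives 39300 nM, a higher number, and compound 2 `COc1ccc(C(=O)C=CNc2cc(-c3ccccc3)nn2-c2ccccc2)cc1` gives 2030 nM, a lower one. Both gaps to compound 1 lie beyond the usual scatter of repeated measurements.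

Compound 4 `N#Cc1c(-c2ccccc2)nc2c(c(-c3ccccc3)nn2-c2ccccc2)c1-c1ccc(N2CCCCC2)cc1` keeps the core of compound 1 and changes one group, with hydrogen in place of methoxy on an aromatic carbon, so that 4-methoxyphenyl becomes phenyl (hydrogen in place of methoxy on an aromatic carbon). Within the data shown here, no pair of measured compounds shows this change on its own, and compound 2 and compound 3 differ from compound 1 in far more than one place, so the data offer only a weak guide. With so little to go on, the expectation is of no shift beyond the scatter in this assay. The estimated step of a 1.1-fold higher number from compound 1 to compound 4 (0.05 log units; within the scatter) is therefore small. For compound 4 the expected value is 14000 nM, within an estimated range of 5000 nM to 35000 nM.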

Compound 4, half-maximal inhibitory concentration: 30900 nM
Compound 4: the middle estimate sits 2.2-fold (0.34 log units) below what was measured; the measured number falls inside the stated range.
By their numbers in this assay, from the lowest: compound 2; then compound 1; then compounds 4 and 3 (each within the scatter of the next).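

In this assay, putting hydrogen in place of methoxy gives a 2.5-fold higher number from compound 1 to compound 4 (0.39 log units; beyond the scatter), a modest step beyond the scatter. Among these compounds, this is the first direct reading of this single change, which the earlier compounds could not give: on this ring, para to a large group, the compound with methoxy is the stronger inhibitor of the pair, so the group is not idle at this position. No measurement at hand explains the shift.

Going by these compounds, whether this advantage is specific to methoxy remains open, and a hydroxyl group, a fluorine atom or an amine at the same place would help to settle that. Also open, on these data alone, is whether the same change would have a similar effect on another core, such as that of compound 2, which also carries a 4-methoxyphenyl group.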